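The source may hold more compounds than are shown below. What is called first, only, known or untested is meant among the compounds shown, and "the series" means these compounds.

In a functional assay on SNU-423 cells (Homo sapiens) for inhibition, read by MTT assay, with a stated time of 72 h (a lower number here means a stronger inhibitor, a higher number a weaker inhibitor), compound 3 `Nc1nc2cc(-c3nn(CCCCC(=O)NO)c4ncnc(N)c34)ccc2o1` gives 3030 nM, the lower of the two actual numbers. Compound 2 `Nc1ncnc2c1c(-c1cnc3[nH]ccc3c1)nn2CCCCCCC(=O)NO` gives 7500 nM, a higher number by more than the usual scatter, but its structure differs in more than one place, so it says little about chain length alone. For compound 1 `Nc1nc2cc(-c3nn(CCCCCCCCCC(=O)NO)c4ncnc(N)c34)ccc2o1` there is only a limit, > 50000 nM.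

Compound 4 `Nc1nc2cc(-c3nn(CCCCCC(=O)NO)c4ncnc(N)c34)ccc2o1` has not yet been measured. The structural difference is this: (hydroxycarbamoyl)methyl in place of hydroxycarbamoyl on a saturated chain carbon, four bonds along the chain from an aromatic nitrogen. It places (hydroxycarbamoyl)methyl in place of hydroxycarbamoyl on a saturated chain carbon, four bonds along the chain from an aromatic nitrogen, so 3-(hydroxycarbamoyl)propyl becomes 4-(hydroxycarbamoyl)butyl and the chain grows.

For the measured compounds named here, one measured step bears on this change: an at least 16-fold lower number from compound 1 to compound 3 (1.21 log units; beyond the scatter), a large step in which hydroxycarbamoyl takes the place of 5-(hydroxycarbamoyl)pentyl at the same chain carbon. There, the shorter chain gave the lower number. That step covers a much bigger change in the chain than the one at hand, and one end of it is only a limit, so it gives a direction but no exact size. A slightly higher number is therefore expected, with no step beyond the scatter. The expected step is a 1.3-fold higher number from compound 3 to compound 4 (0.10 log units; within the scatter). For compound 4 the estimated value is 3800 nM, with a range of 1200 nM to 12000 nM.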

Compound 4, half-maximal inhibitory concentration: 12600 nM
Beside the measured number, compound 4's estimate is 3.3-fold (0.52 log units) below it, and the stated range ends below it.
By their numbers in this assay, from the lowest: compound 3; then compounds 2 and 4 (each within the scatter of the next). At a limit, above all of these: compound 1.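

In this assay, the step from 3-(hydroxycarbamoyl)propyl to 4-(hydroxycarbamoyl)butyl gives a 4.2-fold higher number from compound 3 to compound 4 (0.62 log units; beyond the scatter), so even this small lengthening of the chain at this place moves the number by more than the scatter, which the earlier step, spanning a far larger change, could not show. Compound 4 still sits on the low side of the compound with the longest chain, with an at least 3.9-fold lower number from compound 1 to compound 4 (0.59 log units; beyond the scatter), so among the three compounds that share this core and differ only in the chain, the number rises as the chain grows, and none of the three goes against this. The value of compound 1 is a limit and not a number, so the top end of this trend has no exact size: the limit of > 50000 nM in this assay, at which 1 of the 4 values shown sits.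

Going by these compounds, it remains open whether the trend continues downward with a shorter chain such as 2-(hydroxycarbamoyl)ethyl or (hydroxycarbamoyl)methyl, or whether the number turns upward again at some shorter length. On these data alone, it is equally open how the number would respond to a carboxylic acid or a primary amide in place of the hydroxycarbamoyl group at the end of the chain.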